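Octylsulfanyl in place of isopropylamino: notes on the series

A few compounds are considered here, and "the series" means these few. Any claim that something is new, unique, unknown or untested is made for them only; others in the source may bear on it.

In an ADME assay on CCRF-HSB-2 cells (Homo sapiens) for cytotoxicity, with a stated time of 7 days (a higher number here means that more compound is tolerated, a lower number that less compound is tolerated), compound 3 `CC(C)Nc1nc(N)nc2c1ncn2/C=C1/CC1(CO)CO` gives > 20000 nM, which is a limit and not a number. Compound 1 `COCCOc1nc(N)nc2c1ncn2/C=C1/CC1(CO)CO` gives > 20000 nM, also a limit. Going by the values given here, compound 2 `CCCSc1nc(N)nc2c1ncn2/C=C1/CC1(CO)CO` gives 98000 nM, the only true number.

The next change leads to compound 4 `CCCCCCCCSc1nc(N)nc2c1ncn2/C=C1/CC1(CO)CO`: octylsulfanyl in place of isopropylamino on an aromatic carbon. In words, octylsulfanyl replaces isopropylamino on an aromatic carbon.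

Among the compounds with values here, two measured steps bear on this, and neither gives a size: a step that the limit leaves unreadable from compound 1 to compound 2 and a step that the limit leaves unreadable from compound 2 to compound 3. The best anchor is therefore compound 2 at 98000 nM, whose propylsulfanyl group is the closest group in the series to octylsulfanyl. A somewhat lower tolerated concentration than that is expected for the longer chain, but this direction is held only loosely. The expected change is a step that the limit leaves unreadable from compound 3 to compound 4. A report of only a limit also remains quite possible. For compound 4 the estimated value is 40000 nM, with an expected range from 10000 nM to 120000 nM.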

Compound 4, half-maximal cytotoxic concentration: 60000 nM
The estimate for compound 4 lay 1.5-fold (0.18 log units) below the measured number, within the range that was stated.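

Pentyl in place of hydrogen on the chain, in this assay, gives a 1.6-fold lower number from compound 2 to compound 4 (0.21 log units; within the scatter), so the propylsulfanyl and octylsulfanyl compounds cannot be told apart at this position. Going by these compounds alone, this is the first step with a true number at both ends, and it shows that the chain length spanned by these two compounds leaves the read-out within the scatter. The steps to compound 4 from compound 1 and from compound 3 cannot be read, because each of those two compounds carries only a limit: the limit of > 20000 nM in this assay, at which 2 of the 4 values shown sit.

How the sulfanyl compounds compare with the 2-methoxyethoxy and isopropylamino compounds therefore stays unresolved. Also open, as far as these compounds go, is what a longer chain such as dodecylsulfanyl, or an amine at the end of the octyl chain, would give at this position.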